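The compounds below may be only part of what the source reports. "The series", "measured", "known", "first", "only" and "open" are said of these compounds alone.

Three compounds share one core and are compared in a functional assay on SGC-7901 cells (Homo sapiens) for cytotoxicity, read by MTT assay, with a stated time of 48 h; on this read-out higher numbers stand for weaker inhibition and lower numbers for stronger inhibition. Compound 1 `CCOc1ccccc1-c1nnc(SCCn2c([N+](=O)[O-])cnc2C)o1` gives 30300 nM. Compound 3 `Cc1ncc([N+](=O)[O-])n1CCSc1nnc(-c2ccccc2[N+](=O)[O-])o1` differs from it by nitro in place of ethoxy on an aromatic carbon and in this assay compound 3 gives 30000 nM, so that the step of a 1.0-fold lower number from compound 1 to compound 3 (0.00 log units; within the scatter) is flat. Compound 2 `CCOc1ccc(-c2nnc(SCCn3c([N+](=O)[O-])cnc3C)o2)cc1` has the same atoms as compound 1 joined differently; the difference between the two cores is not broken down here. In this assay compound 2 gives 14100 nM, the lowest of the three numbers, with both steps to the others beyond the scatter. Compound 4 `Cc1ncc([N+](=O)[O-])n1CCSc1nnc(-c2ccc([N+](=O)[O-])cc2)o1` is not yet measured and differs from compound 2 by nitro in place of ethoxy on an aromatic carbon. This is the same kind of change as that from compound 1 to compound 3, though there the group sits ortho to a large group and here para to a large group. Because the step of a 1.0-fold lower number from compound 1 to compound 3 (0.00 log units; within the scatter) was flat, compound 4 is expected to give 14000 nM, between 6000 nM and 32000 nM. From compound 2 the expected step is a 1.0-fold lower number from compound 2 to compound 4 (0.00 log units; within the scatter).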

Compound 4, half-maximal inhibitory concentration: 12200 nM
Compound 4: the middle estimate sits 1.1-fold (0.06 log units) above what was measured; low and high end bracket the measured number.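

In this assay, nitro in place of ethoxy on an aromatic carbon gives a 1.2-fold lower number from compound 2 to compound 4 (0.06 log units; within the scatter), and the change behaves alike on the two cores: the same change on two cores in this assay, a 1.0-fold lower number (0.00 log units; within the scatter) from compound 1 to compound 3 and a 1.2-fold lower number (0.06 log units; within the scatter) from compound 2 to compound 4, 1.1-fold (0.06 log units) apart, within the scatter of two such steps. Within this series the swap therefore carries over as a flat step, whether the group sits ortho or para to a large group. Among the compounds shown here, this rests on only two pairs, so it does not show that the step would stay flat on any other core, and a flat step does not explain why the number holds.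

The compounds shown leave open whether an amine or a carboxylic acid in the place of ethoxy or nitro would shift the number. They also leave open what a longer chain in the sulfur-bearing linker would do.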